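Removing the Methoxy Group from Compound 1

The source may report more compounds than this note shows. Statements on the series, on what has been measured and on what is new or still open speak of the compounds shown alone.

Measured in a functional assay on KM12 cells (Homo sapiens) for inhibition, read by sulforhodamine B assay, with a stated time of 48 h, tested at 10 uM; on this read-out higher numbers stand for more inhibition of growth at the one concentration tested and lower numbers for less inhibition of growth:
- Compound 1 `COc1ccc(-c2nc3sc(-c4ccccc4)cn3n2)cc1` gives 70%
- Compound 2 `COc1cc(-c2nc3sc(-c4ccccc4)cn3n2)cc(OC)c1OC` gives 14%

Only these two compounds have been measured in this assay. Within the data shown here, compound 1 stands higher, and compound 2 is its only neighbour, lying below it by a margin well beyond the usual scatter. The next compound to be tested is compound 3 `c1ccc(-c2nc3sc(-c4ccccc4)cn3n2)cc1`. It differs from compound 1 by hydrogen in place of methoxy on an aromatic carbon, para to a large group (hydrogen in place of methoxy on an aromatic carbon).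

Among the measured compounds shown here, no measured pair yet isolates a single change, so the size of this step cannot be read directly from the data. The spread between compound 1 at 70% and compound 2 at 14% shows only that growth inhibition can differ widely among compounds sharing this core. A moderate fall in inhibition is expected, with real uncertainty about its size. The estimated step is a number 25 percentage points lower from compound 1 to compound 3 (beyond the scatter), which would lie beyond the scatter. Compound 3 is expected to give 45%, with an estimated range from 15% to 75%.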

Compound 3, percent growth inhibition at one concentration: 18%
Beside the measured number, compound 3's estimate is 27 percentage points above it; low and high end bracket the measured number.
By their numbers in this assay, from the lowest: compounds 2 and 3 (each within the scatter of the next); then compound 1.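

Among these compounds, the first comparison in this assay that isolates a single change shows that this place on the shared core is far from indifferent: hydrogen in place of methoxy on an aromatic carbon, para to a large group, gives a number 52 percentage points lower from compound 1 to compound 3 (beyond the scatter). With methoxy at this place, compound 1 gives 70%, whereas with only hydrogen there, compound 3 gives 18%, so most of the growth inhibition seen at the one concentration tested is lost when this single group leaves. The data offer no independent measurement that could explain why this change has so large an effect.

The compounds shown leave open whether methoxy is specifically required at this place, or whether a hydroxyl, an ethoxy group, a fluorine atom or an amine could keep the growth inhibition of compound 1. They also leave open whether the same step would appear with a different group on the other phenyl ring of the core, such as a chlorine atom or a methyl group.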